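This account rests on a few compounds, and the source may have more. Where it says the series, first, only, none or still open, it means among the compounds named here.

Measured so far:
- compound 1 `O=S(=O)(CSc1nnc(Br)n1Cc1ccc(Br)c2ccccc12)Nc1ccc(F)nc1`; in an assay on HEK293 cells for inhibition of solute carrier family 22 member 12 (Homo sapiens) (a lower number here means a stronger inhibitor, a higher number a weaker inhibitor), compound 1 gives 1550 nM
- compound 2 `O=S(=O)(CSc1nnc(Br)n1Cc1ccc(Br)c2ccccc12)Nc1cc(Cl)cnc1Cl`; in this assay compound 2 gives 2790 nM

Compound 2 holds the higher of the two numbers in this assay, but the step of a 1.8-fold higher number from compound 1 to compound 2 (0.26 log units; within the scatter) lies within the scatter, so no order between the two compounds can be read from it. Compound 3 `O=S(=O)(CSc1nnc(Br)n1Cc1ccc(Br)c2ccccc12)Nc1ccc(Cl)nc1Cl` keeps the whole core of compound 2 and differs only at the sulfonamide nitrogen: 2,6-dichloropyridin-3-yl in place of 2,5-dichloropyridin-3-yl on a sulfonamide nitrogen. Among the measured compounds shown here, the single measured step that bears on this position, a 1.8-fold higher number from compound 1 to compound 2 (0.26 log units; within the scatter), exchanged one substituted pyridinyl for another without a change beyond the scatter, and nothing else measured supports a shift in either direction. For compound 3 the expected step is therefore a 1.1-fold lower number from compound 2 to compound 3 (0.05 log units; within the scatter), a change no larger than the scatter. Compound 3 is estimated at 2500 nM in this assay, with a range from 1000 nM to 6500 nM.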

Compound 3, half-maximal inhibitory concentration: 1660 nM
Compound 3: middle estimate off by 1.5-fold (0.18 log units), on the high side; the range from low to high includes it.
By their numbers in this assay, from the lowest: compounds 1, 3 and 2 (each within the scatter of the next).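

Putting 2,6-dichloropyridin-3-yl in place of 2,5-dichloropyridin-3-yl on the sulfonamide nitrogen gives a step (a 1.7-fold lower number from compound 2 to compound 3 (0.23 log units; within the scatter)) that stays within the scatter, so rearranging the same atoms does not separate these two compounds in this assay. The exchange for 6-fluoropyridin-3-yl likewise gives no readable difference (a 1.1-fold higher number from compound 1 to compound 3 (0.03 log units; within the scatter)), so the three substituted pyridinyl groups shown cannot be ordered at this position. No measurement is available to set this result against any other property of these compounds.

From the compounds shown here alone, whether a group of another kind on the sulfonamide nitrogen, such as an unsubstituted phenyl, a carboxylic acid or a longer alkyl chain, would shift the number beyond the scatter remains open. Also open, going by these compounds, is how the number responds to a change elsewhere on the shared core, which all three compounds keep.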